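The source may report more compounds than this note shows. Statements on the series, on what has been measured and on what is new or still open speak of the compounds shown alone.

Within the data shown here, compound 1 `O=C(O)CCc1ccc(NCc2ccc(Cl)cc2)cc1` is one of three compounds measured in a functional assay on CHO cells for agonist activity at Free fatty acid receptor 1 (Homo sapiens), read by reporter gene assay (a higher number here means a larger maximal response, a lower number a smaller maximal response), where compound 1 gives 111%. Compound 3 `O=C(O)CCc1ccc(NCc2ccc(Cl)c(Cl)c2)cc1` differs from compound 1 by chloro in place of hydrogen on an aromatic carbon; in this assay compound 3 gives 117%, and the step of a number 6 percentage points higher from compound 1 to compound 3 (within the scatter) lies within the scatter. Compound 2 `O=C(O)C1CC1c1ccc(NCc2cccc(Oc3ccccc3)c2)cc1` gives 74% in this assay, a number well below that of compound 1 and beyond the scatter, but compound 2 differs from compound 1 in more than one place, so no single change can be read from it.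

Compound 4 `N#Cc1ccc(CNc2ccc(CCC(=O)O)cc2)cc1` is not yet measured. It differs from compound 1 as follows: cyano in place of chloro on an aromatic carbon. Among the measured compounds shown here, no measured step exchanges one group for another at this position; the only step at a related place, a number 6 percentage points higher from compound 1 to compound 3 (within the scatter), was within the scatter. On that basis no step beyond the scatter is expected in this assay, and the expected step is a number 6 percentage points lower from compound 1 to compound 4 (within the scatter). Compound 4 is therefore estimated to give 105% in this assay, with a range from 85% to 125%.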

Compound 4, largest response reached (reported as percent of maximum), in percent of the reference or control that the assay uses: 49%
The estimate for compound 4 lay 56 percentage points above the measured number; the whole stated range lies above it.
By their numbers in this assay, from the lowest: compound 4; then compound 2; then compounds 1 and 3 (each within the scatter of the next).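

In this assay, exchanging chloro for cyano on the aromatic carbon para to a large group gives a number 62 percentage points lower from compound 1 to compound 4 (beyond the scatter). Among these compounds, this is the first step beyond the scatter at this place: the earlier change on the same ring, a number 6 percentage points higher from compound 1 to compound 3 (within the scatter), kept this chloro and stayed within the scatter, so it gave no sign that the maximal response depends on the group held here. Among these compounds, the response therefore changes sharply with this single exchange, but nothing available explains the drop. On these data alone, it remains open whether bromo, methyl or methoxy at this place would keep the response of compound 1 or lower it as cyano does. As far as these compounds go, it is also open whether cyano would give a similar step with the second chloro of compound 3 present.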